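Three Measured Analogues and a Fourth Still to Be Estimated

The source may hold more compounds than are shown below. What is called first, only, known or untested is meant among the compounds shown, and "the series" means these compounds.

Compound 1, `C=C(C)[C@@H]1CC=C(C)/C(=N/NC(=O)Nc2nnc(-c3ccc(Cl)cc3)o2)C1`: 300 mg/kg
Compound 2, `C=C(C)[C@@H]1CC=C(C)/C(=N/NC(=O)Nc2nnc(-c3ccc([N+](=O)[O-])cc3)o2)C1`: 300 mg/kg
Compound 3, `C=C(C)[C@@H]1CC=C(C)/C(=N/NC(=O)Nc2nnc(-c3cccc(O)c3)o2)C1`: 300 mg/kg

Of the compounds shown here, three sharing one core have been tested in a functional assay on the whole organism (strain Swiss albino) with Mus musculus as the target, with a stated time of 4 h; on this read-out higher numbers stand for an effect only at larger amounts of compound and lower numbers for an effect already at smaller amounts. The result is the same for all three: no change at the digits printed from compound 1 to compound 2 (within the scatter), no change at the digits printed from compound 1 to compound 3 (within the scatter) and no change at the digits printed from compound 2 to compound 3 (within the scatter). Compound 3 therefore stands level with compound 1 and compound 2 at the digits shown; its nearest neighbour is compound 1 and its furthest is compound 2, but neither distance goes beyond the scatter of the method.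

The step now followed leads from compound 3 to compound 4, `C=C(C)[C@@H]1CC=C(C)/C(=N/NC(=O)Nc2nnc(-c3ccc(O)cc3)o2)C1`. The change is 4-hydroxyphenyl in place of 3-hydroxyphenyl on an aromatic carbon. The two have the same atoms, joined differently, on an aromatic carbon of a five-membered aromatic ring with 2 nitrogen and 1 oxygen. The measured steps that bear on it are the exchanges of the aryl group on that same carbon, from chloro to nitro to 3-hydroxyphenyl, and each of them left the read-out unchanged at the digits shown. Since no exchange of this group has so far moved the read-out beyond the scatter, compound 4 is expected to show no change at the digits printed from compound 3 to compound 4 (within the scatter) in this assay. The estimate for compound 4 in this assay is 300 mg/kg, with an expected range from 150 mg/kg to 600 mg/kg.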

Compound 4, minimum effective dose: 300 mg/kg
Compound 4: the middle estimate sits on the measured number at the digits printed, and the stated range covers the measured number.
By their numbers in this assay, from the lowest: compounds 1, 2, 3 and 4 (each within the scatter of the next).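

In this assay, the exchange of 3-hydroxyphenyl for 4-hydroxyphenyl gives no change at the digits printed from compound 3 to compound 4 (within the scatter), so moving the hydroxy group on the phenyl ring, with the same atoms kept, has now been read at this position and leaves the read-out where it was. The direct exchanges add that hydroxy in place of nitro gives no change at the digits printed from compound 2 to compound 4 (within the scatter) and hydroxy in place of chloro gives no change at the digits printed from compound 1 to compound 4 (within the scatter), so 4-chlorophenyl, 4-nitrophenyl and 4-hydroxyphenyl cannot be told apart by this read-out. Nothing in the material at hand offers an account of why these four compounds read alike.

The compounds shown leave open whether any group on this aromatic carbon can move the read-out beyond the scatter, since every aryl group here is a phenyl ring carrying a single chloro, nitro or hydroxy group, and an amine, a carboxylic acid or a longer alkyl chain on that ring would test this further. They also leave open whether replacing the phenyl ring itself, or changing another part of the shared core, would shift the minimum effective dose.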